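The compounds below may be only part of what the source reports. "The series", "measured", "known", "first", "only" and "open" are said of these compounds alone.

Measured in a functional assay on MGC-803 cells (Homo sapiens) for antiproliferative activity, read by MTT assay, with a stated time of 72 h; on this read-out higher numbers stand for weaker inhibition and lower numbers for stronger inhibition:
- compound 1 `CCCSc1nc(N/N=C(\C)c2ccccc2O)c2nnn(Cc3ccc(Cl)cc3)c2n1`: 7100 nM
- compound 2 `CCCSc1nc(N/N=C(\C)c2ccccc2O)c2nnn(Cc3ccccc3Cl)c2n1`: 35000 nM
- compound 3 `CCCSc1nc(N/N=C/c2cccs2)c2nnn(Cc3ccccc3)c2n1`: > 64000 nM

Compound 3 gives > 64000 nM, which is a limit of this assay and not a number. Among the compounds with values here, this is the only limit among the values so far: the limit of > 64000 nM in this assay, at which 1 of the 3 values shown sits. Compound 4 `CCCSc1nc(N/N=C/c2ccccc2)c2nnn(Cc3ccccc3)c2n1` has not been measured yet. It differs from compound 3 in one place: phenyl in place of thiophen-2-yl on a carbon with a double bond to nitrogen. Within the data shown here, no measured step touches that place. Among the measured compounds shown here, the only step available, a 4.9-fold higher number from compound 1 to compound 2 (0.69 log units; beyond the scatter), concerns the chlorophenyl group and serves only as a rough guide to size. A step of similar modest size is therefore expected in this assay, with no firm direction. The expected step is a step that the limit leaves unreadable from compound 3 to compound 4. For compound 4, the estimate is 70000 nM, within a range of 25000 nM to 200000 nM.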

Compound 4, half-maximal inhibitory concentration: > 64000 nM
Compound 4: only a limit was reported; the forecaster's own chance of this, stated with the estimate: 60%; the middle value lies beyond the limit too.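

No step from compound 3 to compound 4 can be read, because both results are limits of the assay and not numbers: the limit of > 64000 nM in this assay, at which 2 of the 4 values shown sit.

Going by these compounds, whether phenyl or thiophen-2-yl gives stronger inhibition in this assay remains open.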